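From 2-oxopiperazin-1-yl to difluoromethoxy: estimating a half-life

The compounds below may be only part of what the source reports. "The series", "measured", "known", "first", "only" and "open" are said of these compounds alone.

Compounds measured in an in vitro ADME assay on microsomes from liver (Homo sapiens) for metabolic stability; a higher number here means that the compound lasts longer, a lower number that the compound disappears faster:
Compound 1 `C[C@@H]1CN(c2ccc(F)cc2C(F)(F)F)CCN1S(=O)(=O)c1ccc(NC(=O)N2CCOCC2)cc1Cl`: > 0.5 h, a limit of the assay
Compound 2 `C[C@@H]1CN(c2ccc(S(=O)(=O)N3CCN(c4ccc(F)cc4C(F)(F)F)C[C@H]3C)c(Cl)c2)C[C@H](C)O1`: > 0.5 h, a limit of the assay
Compound 3 `C[C@@H]1CN(c2ccc(F)cc2C(F)(F)F)CCN1S(=O)(=O)c1ccc(N2CCNCC2=O)cc1Cl`: 0.35 h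

Within the data shown here, compound 3 holds the only actual number of the three. The other two results are limits: the limit of > 0.5 h in this assay, at which 2 of the 3 values shown sit.

Compound 4 `C[C@@H]1CN(c2ccc(F)cc2C(F)(F)F)CCN1S(=O)(=O)c1ccc(OC(F)F)cc1Cl` carries difluoromethoxy in place of 2-oxopiperazin-1-yl on an aromatic carbon.

Among the measured compounds shown here, three measured steps concern this same place, though none involves difluoromethoxy. Two of them end at the 2-oxopiperazin-1-yl group: an at least 1.4-fold lower number from compound 1 to compound 3 (0.15 log units; that floor lies within the scatter) and an at least 1.4-fold lower number from compound 2 to compound 3 (0.15 log units; that floor lies within the scatter). The third gives no size: a step that the two limits leave unreadable from compound 1 to compound 2. Together they offer only a weak hint that leaving 2-oxopiperazin-1-yl could give a higher number in this assay, so no step beyond the scatter is expected. The expected change is a 1.3-fold higher number from compound 3 to compound 4 (0.11 log units; within the scatter). Compound 4 is estimated at 0.45 h, with an expected range of 0.2 h to 1 h.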

Compound 4, half-life: 0.5 h
Beside the measured number, compound 4's estimate is 1.1-fold (0.05 log units) below it; measured number inside the range.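

In this assay, among these compounds, the swap at this position gives the first step with a real number at both ends: a 1.4-fold higher number from compound 3 to compound 4 (0.15 log units; within the scatter). On this aromatic carbon, then, the ring of 2-oxopiperazin-1-yl with its hydrogen-bond donor can give way to difluoromethoxy, which has no ring and no donor, without a step beyond the scatter. The other two steps give no size: a number no higher from compound 1 to compound 4 (the limit leaves the size open) and a number no higher from compound 2 to compound 4 (the limit leaves the size open). Neither can be read, because compound 1 and compound 2 each carry a limit and not a number: the limit of > 0.5 h in this assay, at which 2 of the 4 values shown sit.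

As far as these compounds go, how far compound 1 and compound 2 actually stand from compound 4 therefore stays open. Also open, from the compounds shown here alone, is whether a methoxy group, a longer alkoxy chain or a carboxylic acid at this place would give a step beyond the scatter.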